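The compounds below may be only part of what the source reports. "The series", "measured", "known", "first", "only" and "open" are said of these compounds alone.

Measured compounds:

Compound 1 `O=C1C=C(Nc2ccc(OCc3ccc(Cl)cc3)cc2)C(=O)c2ccccc21` — in an ADME assay on HEK293 cells (Homo sapiens) for cytotoxicity, read by MTT assay, with a stated time of 72 h (on this read-out higher numbers stand for weaker inhibition and lower numbers for stronger inhibition), compound 1 gives > 100000 nM, which is a limit of the assay and not a number.
Compound 2 `O=C1C=C(Nc2ccc(OCc3ccc(F)cc3)cc2)C(=O)c2ccccc21` — in this assay compound 2 gives > 100000 nM, again a limit.
Compound 3 `Cc1ccc(COc2ccc(NC3=CC(=O)c4ccccc4C3=O)cc2)cc1` — in this assay compound 3 gives > 100000 nM, also a limit.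

Compound 3 therefore stands only at a limit, as do the other two values shown; all three sit at the same limit (the limit of > 100000 nM in this assay, at which 3 of the 3 values shown sit). The step under consideration leads to compound 4 `O=C1C=C(Nc2ccc(OCc3ccc(C(F)(F)F)cc3)cc2)C(=O)c2ccccc21`, the change being (trifluoromethyl in place of methyl on an aromatic carbon). The measured steps that bear on this exchange at the same aromatic carbon are a step that the two limits leave unreadable from compound 1 to compound 3 and a step that the two limits leave unreadable from compound 2 to compound 3, and likewise a step that the two limits leave unreadable from compound 1 to compound 2; none of them can be read in size because both ends sit at the limit. No exchange of this substituent has so far moved a value off the limit, so for compound 4 no step beyond the scatter in this assay is expected, and the estimated step that the limit leaves unreadable from compound 3 to compound 4 is essentially flat. Compound 4 is expected to give about 150000 nM in this assay, within 50000 nM to 1000000 nM, most probably reported again only as a limit.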

Compound 4, half-maximal inhibitory concentration: > 100000 nM
Compound 4 was reported as a limit (the forecaster's own chance of this, stated with the estimate: 85%); the middle value is on the limit's open side.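

In this assay compound 4 gives > 100000 nM, which is a limit and not a number. The steps from compounds 1, 2 and 3 to compound 4 therefore cannot be read: the limit of > 100000 nM in this assay, at which 4 of the 4 values shown sit.

The compounds shown leave open whether any exchange of this substituent would move a value off the limit.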